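Working notes: from compound 3 to compound 4

The source may hold more compounds than are shown below. What is called first, only, known or untested is meant among the compounds shown, and "the series" means these compounds.

Measured compounds:
compound 1 `O=S(=O)(/C=C/c1ccc(Br)cc1)Nc1ccc(F)cc1`
compound 2 `COc1ccc(NS(=O)(=O)/C=C/c2c(OC)cc(OCCCC(=O)O)cc2OC)cc1O`
compound 3 `COC(=O)CNc1cc(NS(=O)(=O)/C=C/c2c(OC)cc(OC)cc2OC)ccc1OC`

In a functional assay on K562 cells (Homo sapiens) for cytotoxicity, read by trypan blue exclusion, with a stated time of 96 h (a higher number here means a weaker inhibitor, a lower number a stronger inhibitor), compound 1 gives 10000 nM and compound 2 gives 10000 nM. Compound 3 gives 350 nM in this assay, the lowest of the three numbers, and its gap to each of the other two lies beyond the scatter. No pair among these differs in one place, so no single step can be read from them.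

Compound 4 `COc1cc(OC)c(/C=C/S(=O)(=O)Nc2ccc(OC)c(NC(C(=O)O)c3ccc(F)cc3)c2)c(OC)c1` is not yet measured. It differs from compound 3 as follows: carboxy(4-fluorophenyl)methyl in place of (methoxycarbonyl)methyl on a nitrogen on an aromatic ring. Without a measured step of this kind, only a moderate weakening within a wide margin is expected. The expected step is a 2.0-fold higher number from compound 3 to compound 4 (0.30 log units; within the scatter). Compound 4 is estimated at 700 nM, between 150 nM and 3500 nM.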

Compound 4, half-maximal inhibitory concentration: 20 nM
Beside the measured number, compound 4's estimate is 35-fold (1.54 log units) above it, and the stated range ends above it.
By their numbers in this assay, from the lowest: compound 4; then compound 3; then compounds 1 and 2 (each within the scatter of the next).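

In this assay, the nitrogen on an aromatic ring accepts a much larger substituent than the (methoxycarbonyl)methyl group: carboxy(4-fluorophenyl)methyl in its place gives an 18-fold lower number from compound 3 to compound 4 (1.24 log units; beyond the scatter). This single change replaces a methyl ester with a carboxylic acid and also adds the 4-fluorophenyl ring, so the step shows their combined result only. Nothing measured here accounts for the size of the step.

Which part carries the gain remains open. An unsubstituted phenyl in place of 4-fluorophenyl, or a methyl ester or primary amide in place of the carboxylic acid, would separate the contributions.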